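Swapping a chlorine for an oxazole-bearing ether

The source may report more compounds than this note shows. Statements on the series, on what has been measured and on what is new or still open speak of the compounds shown alone.

Measured compounds:
compound 1 `O=C(O)CCn1c(=O)oc2cc(Cl)c(Cl)cc21`, 1.61
compound 2 `Cc1ccc([C@@H](C)Oc2cc3onc(CCC(=O)O)c3cc2Cl)nn1`, 2.97
compound 3 `C[C@@H](Oc1cc2sc(=O)n(CCC(=O)O)c2cc1Cl)c1ccccn1`, 1.81

Of the compounds shown here, three have been measured in a physicochemical assay for lipophilicity, read by HPLC, at pH 7.4; a higher number here means a more lipophilic compound, a lower number a more polar compound. Compound 1 sits lowest of the three; its nearest neighbour is compound 3, whose number is higher by an amount that lies within the usual scatter, while compound 2 stands furthest away, higher by a margin that clearly exceeds it.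

Compound 4 `C[C@@H](Oc1cc2oc(=O)n(CCC(=O)O)c2cc1Cl)c1ncco1` is the next compound to be examined. It differs from compound 1 in one place: a group of 8 heavy atoms (5 carbon, 1 nitrogen, 2 oxygen; one five-membered aromatic ring with 2 hetero atoms) in place of one chlorine atom, on an aromatic carbon The chlorine that leaves is small, and what enters is a group of 8 heavy atoms with a five-membered aromatic ring holding two hetero atoms and three hydrogen-bond acceptors.

Going by the values given here, no step between two measured compounds is available to calibrate this exchange, so the expected size of the step in this assay rests on the change itself. A modest rise is expected, since a considerably larger group replaces a single atom, tempered by the acceptors it brings. For compound 4 the estimated value is 1.9, with a range from 1.4 to 2.5, which would mean an expected step of a number 0.29 log units higher from compound 1 to compound 4 (within the scatter).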

Compound 4, distribution coefficient: 1.11
Estimate against measurement, compound 4: 0.79 log units above; the measured number lies below the stated range.
By their numbers in this assay, from the lowest: compound 4; then compounds 1 and 3 (each within the scatter of the next); then compound 2.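

In this assay, putting a group of 8 heavy atoms with a five-membered aromatic ring in place of the chloro group, on the aromatic carbon ortho to a chloro group, gives a number 0.50 log units lower from compound 1 to compound 4 (beyond the scatter). This position can therefore take a much larger group with 3 hydrogen-bond acceptors while the number falls, so in this one pair the heavy-atom count alone does not set the direction of the step. Nothing measured here accounts for that direction.

The compounds shown leave open how a methoxy group, a phenyl ring or an amine would read at this position. They also leave open whether the five-membered aromatic ring or the remainder of the entering group carries the step, and whether it would recur on another core.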